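The source may hold more compounds than are shown below. What is called first, only, known or untested is meant among the compounds shown, and "the series" means these compounds.

Measured compounds and their values in a functional assay on SMMC-7721 cells (Homo sapiens) for inhibition, read by MTT assay, with a stated time of 48 h; on this read-out higher numbers stand for weaker inhibition and lower numbers for stronger inhibition:
compound 1, `Cc1c[nH]c2nc(Nc3ccc4c(c3)CC(=O)N4)nc(NCc3cccnc3N(C)S(C)(=O)=O)c12`: 18700 nM
compound 2, `CN(c1ncccc1CNc1nc(Nc2ccc3c(c2)CC(=O)N3)nc2[nH]cc(F)c12)S(C)(=O)=O`: 73200 nM
compound 3, `CN(c1ncccc1CNc1nc(Nc2ccc3c(c2)CC(=O)N3)nc2[nH]cc(Cl)c12)S(C)(=O)=O`: 21900 nM

Among these three, compound 2 gives the highest number. The step of a 3.9-fold higher number from compound 1 to compound 2 (0.59 log units; beyond the scatter) and the step of a 3.3-fold lower number from compound 2 to compound 3 (0.52 log units; beyond the scatter) both lie beyond the scatter, whereas the step of a 1.2-fold higher number from compound 1 to compound 3 (0.07 log units; within the scatter) stays within it; these steps all concern a single substituent on an aromatic carbon of the shared core.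

Compound 4, `CN(c1ncccc1CNc1nc(Nc2ccc(F)cc2)nc2[nH]cc(F)c12)S(C)(=O)=O`, is not yet measured. It differs from compound 2 at a different place: a group of 7 heavy atoms (6 carbon, 1 fluorine; one six-membered aromatic ring of carbon only) in place of a group of 10 heavy atoms (8 carbon, 1 nitrogen, 1 oxygen; one five-membered non-aromatic ring with 1 hetero atom, one six-membered aromatic ring of carbon only), on a nitrogen on an aromatic ring. For the measured compounds named here, none of the measured steps touches this part of the molecule, so no measured step bears on the change from compound 2 to compound 4, and the size and direction of the step in this assay cannot be read from the data at hand. With compound 2 already standing at 73200 nM, the estimate for compound 4 is placed near that figure with a wide range, giving an expected step of a 1.2-fold higher number from compound 2 to compound 4 (0.09 log units; within the scatter).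

The expected value for compound 4 in this assay is 90000 nM, within a range from 20000 nM to 400000 nM.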

Compound 4, half-maximal inhibitory concentration: 27900 nM
For compound 4 the middle estimate is 3.2-fold (0.51 log units) above the measured one; the range from low to high includes it.
By their numbers in this assay, from the lowest: compounds 1, 3 and 4 (each within the scatter of the next); then compound 2.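

The earlier compounds shown here changed only a single substituent on an aromatic carbon of the shared core, so they could not show whether the group on the nitrogen on an aromatic ring matters. In this assay, replacing the larger two-ring group of compound 2 with 4-fluorophenyl gives a 2.6-fold lower number from compound 2 to compound 4 (0.42 log units; beyond the scatter) and so stronger inhibition, which shows that this second place also affects the read-out and that the hydrogen-bond donor and acceptor of the departing group are not required for inhibition at this level. Nothing available explains why this exchange strengthens inhibition.

For the compounds shown here, this exchange is seen only with fluoro on the core, so its size with the methyl of compound 1 or the chloro of compound 3 remains open. Also open, as far as these compounds go, is how an unsubstituted phenyl, or a phenyl carrying an amine or a carboxylic acid instead of fluorine, would compare.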